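The source may hold more compounds than are shown below. What is called first, only, known or untested is meant among the compounds shown, and "the series" means these compounds.

Measured so far in an ADME assay on HepG2 cells (Homo sapiens) for cytotoxicity, read by MTT assay, with a stated time of 48 h; a higher number here means a weaker inhibitor, a lower number a stronger inhibitor:
Compound 1 `O=S(=O)(c1cccc(-c2ccc3ncnc(Nc4ccc(OCc5cccc(F)c5)c(Cl)c4)c3c2)c1)N1CCCCC1`: > 15000 nM
Compound 2 `O=S(=O)(c1cccc(-c2ccc3ncnc(Nc4ccc(OCc5cccc(F)c5)c(Cl)c4)c3c2)c1)N1CCCC1`: > 15000 nM
Compound 3 `CN(C)S(=O)(=O)c1ccccc1-c1ccc2ncnc(Nc3ccc(OCc4cccc(F)c4)c(Cl)c3)c2c1`: > 15000 nM

Each entry is a limit of the assay and not a number. Compound 3 therefore has no exact position, and it shares its standing with the other two: the limit of > 15000 nM in this assay, at which 3 of the 3 values shown sit.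

The next compound to be tested is compound 4 `Fc1cccc(COc2ccc(Nc3ncnc4ccc(-c5cccc(N6CCCCC6)c5)cc34)cc2Cl)c1`. It keeps the shared core, but 3-(piperidin-1-yl)phenyl takes the place of 2-(dimethylsulfamoyl)phenyl on an aromatic carbon: 3-(piperidin-1-yl)phenyl in place of 2-(dimethylsulfamoyl)phenyl on an aromatic carbon. The sulfonyl group carried by all the measured compounds is gone.

Going by the values given here, only one measured step is available, a step that the two limits leave unreadable from compound 1 to compound 2, and it puts pyrrolidin-1-yl in place of piperidin-1-yl on a sulfonyl sulfur. That step has no readable size, and it does not remove the sulfonyl group, so it gives no size to carry over. No large change can be argued from these data, and the expected step, a step that the limit leaves unreadable from compound 3 to compound 4, is only a rough estimate.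

Compound 4 is expected to stay close to the limit that compound 3 shows at > 15000 nM, and it may well be reported only as a limit. For compound 4 the estimated value is 20000 nM, with an expected range of 8000 nM to 50000 nM.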

Compound 4, half-maximal inhibitory concentration: > 15000 nM
Compound 4 was reported as a limit; the forecaster's own chance of this, stated with the estimate: 65%; the middle value lies beyond the limit too.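

In this assay compound 4 gives > 15000 nM, which is a limit of the assay and not a number. The steps to compound 4 from compound 1, compound 2 and compound 3 therefore cannot be read, and all four compounds share one standing: the limit of > 15000 nM in this assay, at which 4 of the 4 values shown sit.

The compounds shown leave open whether losing the sulfonyl group changes this read-out at all.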